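Phenyl for Benzyl on a Thiourea-Type Nitrogen

A few compounds are considered here, and "the series" means these few. Any claim that something is new, unique, unknown or untested is made for them only; others in the source may bear on it.

Two pairs of compounds were compared in a functional assay on DU-145 cells (Homo sapiens) for cytotoxicity, read by MTT assay; on this read-out lower numbers stand for stronger inhibition and higher numbers for weaker inhibition. Compound 1 `CC(C)[C@H](NC(=S)NCc1ccccc1)c1nc2ccccc2[nH]1` gives 48500 nM. Compound 2 `CC(C)[C@H](NC(=S)Nc1ccccc1)c1nc2ccccc2[nH]1` gives 12300 nM in this assay. The change between them, (phenyl in place of benzyl on an amide-type nitrogen), produced a 3.9-fold lower number from compound 1 to compound 2 (0.60 log units; beyond the scatter). Compound 3 `C[C@@H](NC(=S)NCc1ccccc1)c1nc2ccccc2[nH]1` carries a different core; the difference between the cores of compound 1 and compound 3 is not broken down here. In this assay compound 3 gives 28700 nM. Compound 4 `C[C@@H](NC(=S)Nc1ccccc1)c1nc2ccccc2[nH]1` has not yet been measured. It differs from compound 3 by phenyl in place of benzyl on an amide-type nitrogen, at the same place as before, so the change is the same one. For the measured compounds named here, for compound 4 the expected step is a 3.8-fold lower number from compound 3 to compound 4 (0.58 log units; beyond the scatter), because a 3.9-fold lower number from compound 1 to compound 2 (0.60 log units; beyond the scatter) is the only earlier example of this change. Compound 4 is therefore estimated at 7500 nM, expected to fall between 3000 nM and 20000 nM.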

Compound 4, half-maximal inhibitory concentration: 22100 nM
Compound 4: the middle estimate sits 2.9-fold (0.47 log units) below what was measured; the measured number lies above the stated range.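

In this assay, putting phenyl in place of benzyl on the amide-type nitrogen gave a 1.3-fold lower number from compound 3 to compound 4 (0.11 log units; within the scatter), a step too small to count as a real difference. The same change did not carry over at equal size from one core to the other: the same change on two cores in this assay, a 3.9-fold lower number (0.60 log units; beyond the scatter) from compound 1 to compound 2 and a 1.3-fold lower number (0.11 log units; within the scatter) from compound 3 to compound 4, 3.0-fold (0.48 log units) apart, beyond the scatter of two such steps. For the compounds shown here, with only one pair on each core, this warns against assuming that a step seen on one core will hold on the other, but it does not show which feature of the cores sets the two steps apart.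

The compounds shown carry only benzyl or phenyl on this nitrogen, so a longer chain such as phenethyl remains open. Also open, as far as these compounds go, is whether a phenyl ring carrying a methoxy group would behave alike on both cores.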